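From piperidin-1-yl to ethoxy on a shared core

The source may report more compounds than this note shows. Statements on the series, on what has been measured and on what is new or still open speak of the compounds shown alone.

Compound 1 `Nc1cc2nc(-c3ccccc3)nn(-c3ccccc3)c-2cc1=O`: 950 nM
Compound 2 `O=c1cc2n(-c3ccccc3)nc(-c3ccccc3)nc-2cc1N1CCCCC1`: 1980 nM

Among the compounds with values here, in a functional assay on MCF7 cells (Homo sapiens) for cytotoxicity, read by MTT assay, with a stated time of 72 h (on this read-out higher numbers stand for weaker inhibition and lower numbers for stronger inhibition), compound 2 gives the higher of the two numbers, 1980 nM, and compound 1 is its only neighbour. The next compound is compound 3 `CCOc1cc2nc(-c3ccccc3)nn(-c3ccccc3)c-2cc1=O`, which differs from compound 2 as follows: ethoxy in place of piperidin-1-yl on an aromatic carbon. In words, this is ethoxy in place of piperidin-1-yl on an aromatic carbon. Within the data shown here, no ethoxy compound has been measured yet. Among the measured compounds shown here, only one measured step bears on the change, a 2.1-fold higher number from compound 1 to compound 2 (0.32 log units; beyond the scatter), a modest step that brought in piperidin-1-yl in place of amino. Removing piperidin-1-yl might therefore give back part of that step, so a modest move towards a lower number is expected. The expected change is a 1.5-fold lower number from compound 2 to compound 3 (0.18 log units; within the scatter). For compound 3 the estimated value is 1300 nM, with an expected range of 500 nM to 3400 nM.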

Compound 3, half-maximal inhibitory concentration: > 5000 nM
Compound 3 gave a limit, no number; the forecaster's own chance of this, stated with the estimate: 3%; at least 3.8-fold (0.58 log units) between middle value and limit.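

In this assay compound 3 gives a limit of the assay and not a number, > 5000 nM. The earlier step left open whether replacing piperidin-1-yl with a group of fewer heavy atoms would move the number back towards that of the amino compound, but ethoxy moves it further the same way, with an at least 2.5-fold higher number from compound 2 to compound 3 (0.40 log units; beyond the scatter) and an at least 5.2-fold higher number from compound 1 to compound 3 (0.72 log units; beyond the scatter), so among these three compounds the order does not follow the heavy-atom count of the group and the two nitrogen-bearing groups give the lower numbers. These steps have only a lower bound, and the true size of each stays unknown because compound 3 sits at a limit: the limit of > 5000 nM in this assay, at which 1 of the 3 values shown sits.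

The compounds shown leave open whether the oxygen of ethoxy or its chain matters more at this position. A hydroxyl, a methoxy, a longer alkoxy chain or a morpholine at this carbon could begin to separate these.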